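Piperidin-1-yl in Place of Chloro: Expected Growth Inhibition

The source may hold more compounds than are shown below. What is called first, only, known or untested is meant among the compounds shown, and "the series" means these compounds.

Of the compounds shown here, two have been measured on the same core. Compound 1 `Cc1cnc(Nc2ccc([N+](=O)[O-])cc2)nc1Nc1nc2ccccc2s1` carries a nitro group, and in a functional assay on HCT-116 cells (Homo sapiens) for antiproliferative activity, read by MTT assay, with a stated time of 48 h (on this read-out higher numbers stand for weaker inhibition and lower numbers for stronger inhibition), compound 1 gives 6330 nM. Compound 2 `Cc1cnc(Nc2ccc(Cl)cc2)nc1Nc1nc2ccccc2s1` carries chloro in place of that nitro group. In this assay compound 2 gives only a limit, > 50000 nM, and no number. Going by the values given here, the single measured step, an at least 7.8-fold higher number from compound 1 to compound 2 (0.89 log units; beyond the scatter), is accordingly known only as a bound, which sits at the limit of > 50000 nM in this assay, at which 1 of the 2 values shown sits.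

Compound 3 `Cc1cnc(Nc2ccc(N3CCCCC3)cc2)nc1Nc1nc2ccccc2s1` has not yet been measured. It differs from compound 2 by piperidin-1-yl in place of chloro on an aromatic carbon. Among the compounds with values here, no measured step involves piperidin-1-yl, so the only guidance is that a swap at this same aromatic carbon, from nitro to chloro, moved the number beyond the scatter. Because compound 2 stands at the limit > 50000 nM, any change for compound 3 can only be judged against that bound, and a value at the limit again is a real possibility. Compound 3 is therefore expected to give about 25000 nM in this assay, within a wide range from 5000 nM to 50000 nM. The step of an at least 2.0-fold lower number from compound 2 to compound 3 (0.30 log units; that floor lies within the scatter) that this estimate implies is expected to be small and uncertain, in the direction of somewhat stronger inhibition.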

Compound 3, half-maximal inhibitory concentration: 18700 nM
Compound 3: the middle estimate sits 1.3-fold (0.13 log units) above what was measured; low and high end bracket the measured number.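

In this assay, piperidin-1-yl in place of chloro gives an at least 2.6-fold lower number from compound 2 to compound 3 (0.42 log units; beyond the scatter), which shows that this aromatic carbon, para to a large group, can carry a six-membered non-aromatic ring and still return a measurable number. The size of that step remains a bound, since compound 2 stands at a limit of the assay and not at a number: the limit of > 50000 nM in this assay, at which 1 of the 3 values shown sits. Piperidin-1-yl does not match the nitro group, however, with a 3.0-fold higher number from compound 1 to compound 3 (0.47 log units; beyond the scatter), so the three groups now fall into an order that a single step could not show: nitro gives the strongest inhibition, piperidin-1-yl comes next, and chloro gives the weakest, with compound 2 known only through its limit.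

The three compounds leave open whether the ring of piperidin-1-yl matters at all, which an open-chain dimethylamino group or a morpholine ring at the same carbon would help to settle. They also leave open what sets this order, and where a carboxylic acid, a nitrile or a methoxy group would fall within it.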